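From aminomethyl to carboxy on the shared core

The source may report more compounds than this note shows. Statements on the series, on what has been measured and on what is new or still open speak of the compounds shown alone.

In a functional assay on L1210 cells (Mus musculus) for cytotoxicity (on this read-out higher numbers stand for weaker inhibition and lower numbers for stronger inhibition), compound 1 (`CC[C@H]1OC(n2cc(F)c(=O)[nH]c2=O)[C@H](O)[C@@H]1O`) gives 19 uM and compound 2 (`NC[C@H]1OC(n2cc(F)c(=O)[nH]c2=O)[C@H](O)[C@@H]1O`) gives 38 uM while compound 3 (`CCCCSC[C@H]1OC(n2cc(F)c(=O)[nH]c2=O)[C@H](O)[C@@H]1O`) gives 270 uM for the same core. Compound 2 thus stands within the scatter of compound 1 and well short of compound 3. Compound 4 (`O=C(O)[C@H]1OC(n2cc(F)c(=O)[nH]c2=O)[C@H](O)[C@@H]1O`) carries carboxy in place of aminomethyl on a saturated ring carbon in its place. On the chain carbon the measured steps were a 2.0-fold higher number from compound 1 to compound 2 (0.30 log units; within the scatter) for amino, a 14-fold higher number from compound 1 to compound 3 (1.15 log units; beyond the scatter) for butylsulfanyl and a 7.1-fold higher number from compound 2 to compound 3 (0.85 log units; beyond the scatter) between those two. None of them brings in carboxy, so they guide the size only loosely. A modest move to a higher number is expected, estimated as a 2.6-fold higher number from compound 2 to compound 4 (0.42 log units; beyond the scatter) in this series. Compound 4 is expected at 100 uM with an estimated range of 30 uM to 350 uM in this assay when measured.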

Compound 4, concentration for 50% inhibition: > 1000 uM
Compound 4: a limit, no number; the forecaster's own chance of this, stated with the estimate: 25%; at least 10-fold (1.00 log units) between middle value and limit.
By their numbers in this assay, from the lowest: compounds 1 and 2 (each within the scatter of the next); then compound 3. At a limit, above all of these: compound 4.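

In this assay, for the compounds shown here, carboxy on the saturated ring carbon gives an at least 26-fold higher number from compound 2 to compound 4 (1.42 log units; beyond the scatter), a larger step than any among the earlier compounds. In place of (butylsulfanyl)methyl it gives an at least 3.7-fold higher number from compound 3 to compound 4 (0.56 log units; beyond the scatter), and in place of ethyl it gives an at least 52-fold higher number from compound 1 to compound 4 (1.72 log units; beyond the scatter), so this position tolerates carboxy less well than any of the three earlier groups. The result for compound 4 is a limit, not a number, and the true size of each step stays unknown: the limit of > 1000 uM in this assay, at which 1 of the 4 values shown sits.

On these data alone, what remains open is whether the carboxylic acid itself drives the loss or its placement directly on the ring. A methyl ester, a primary amide or a carboxymethyl group at this position could separate the two.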